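The source may report more compounds than this note shows. Statements on the series, on what has been measured and on what is new or still open speak of the compounds shown alone.

Measured so far:
- compound 1 `COc1ccc(Oc2ccc3c(NCCCNCc4cccc(OC)c4O)ccnc3c2)cc1` gives 317 10^-6 cm/s in an ADME assay for permeability, using PAMPA, with a stated time of 30 min, at pH 7.4; on this read-out lower numbers stand for lower permeability and higher numbers for higher permeability
- compound 2 `COc1cccc(CNCCCNc2ccnc3cc(Cc4ccc(F)cc4Cl)ccc23)c1O` gives 23 10^-6 cm/s in this assay

Going by the values given here, compound 2 stands lowest of the two numbers in this assay; its nearest neighbour is compound 1, and the one measured step shows a 14-fold lower number from compound 1 to compound 2 (1.14 log units; beyond the scatter). That step swapped the whole group on the aromatic carbon of the shared core, so it is only a loose guide to a change made further out on the same side chain.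

Compound 3 `COc1cccc(CNCCCNc2ccnc3cc(CCc4ccccc4)ccc23)c1O` differs from compound 2 at one place: benzyl in place of 2-chloro-4-fluorophenyl on a saturated chain carbon bound to an aromatic carbon. Among the compounds with values here, no measured pair shows this kind of change, so nothing in the data ties it to a particular size or direction of step in this assay. The expectation is therefore a step within the usual scatter, with the estimated change written as a 1.5-fold higher number from compound 2 to compound 3 (0.18 log units; within the scatter).

Compound 3 is expected to give about 35 10^-6 cm/s in this assay, with a likely range from 12 10^-6 cm/s to 100 10^-6 cm/s.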

Compound 3, apparent permeability: 23 10^-6 cm/s
The estimate for compound 3 lay 1.5-fold (0.18 log units) above the measured number; measured number inside the range.
By their numbers in this assay, from the lowest: compounds 2 and 3 (each within the scatter of the next); then compound 1.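

In this assay, the two halogens and the different carbon chain on the aromatic carbon of the shared core leave no readable difference: 2-chloro-4-fluorobenzyl to phenethyl gives no change at the digits printed from compound 2 to compound 3 (within the scatter). Against the group on compound 1, phenethyl in place of 4-methoxyphenoxy gives a 14-fold lower number from compound 1 to compound 3 (1.14 log units; beyond the scatter), a step of the same printed size as the one seen earlier with 2-chloro-4-fluorobenzyl, so the low number no longer rests on a single replacement and 4-methoxyphenoxy stands alone with the high number among these three compounds. No measurement shown here bears on what lies behind either step.

On these data alone, what remains open is which part of 4-methoxyphenoxy goes with the high number, since plain phenoxy, 4-methoxybenzyl or 4-methoxyphenethyl at the same aromatic carbon would separate the oxygen link from the methoxy group. As far as these compounds go, it is also open how far the flat result for the two carbon-linked groups extends, for instance to a longer chain such as 3-phenylpropyl or to a group of another kind, such as an amine or a carboxylic acid.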